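The source may hold more compounds than are shown below. What is called first, only, known or untested is meant among the compounds shown, and "the series" means these compounds.

Three compounds of the series share the core of compound 1 `N#Cc1ccc(-n2nc(-c3ccc(C(F)(F)F)cc3O)nc2-c2ccccc2O)cc1` and differ only in the aromatic ring on the ring nitrogen. In a functional assay on PC-12 cells (Rattus norvegicus) for cytotoxicity, read by MTT assay, with stated times of 2 h and 24 h, tested at 1 uM (on this read-out lower numbers stand for a weaker effect and higher numbers for a stronger effect at the one concentration tested), compound 1 gives 66.6%. Compound 2 `Oc1cc(C(F)(F)F)ccc1-c1nc(-c2ccccc2O)n(-c2ccccc2C(F)(F)F)n1` gives 71% in this assay, and compound 3 `Oc1cc(C(F)(F)F)ccc1-c1nc(-c2ccccc2O)n(-c2cccc(C(F)(F)F)c2)n1` gives 71.5% in this assay. Compound 3 shows the highest of the three numbers, but the two steps leading up to it, a number 0.5 percentage points higher from compound 2 to compound 3 (within the scatter) and a number 4.9 percentage points higher from compound 1 to compound 3 (within the scatter), are both within the scatter, so no order among the three is established.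

Compound 4 `Oc1cc(C(F)(F)F)ccc1-c1nc(-c2ccccc2O)n(-c2cc(C(F)(F)F)cc(C(F)(F)F)c2)n1` is to be measured in this assay. It differs from compound 3 by trifluoromethyl in place of hydrogen on an aromatic carbon, on the ring attached to the aromatic nitrogen. For the measured compounds named here, the steps that bear on this change are those altering this ring: a number 4.4 percentage points higher from compound 1 to compound 2 (within the scatter), a number 4.9 percentage points higher from compound 1 to compound 3 (within the scatter) and a number 0.5 percentage points higher from compound 2 to compound 3 (within the scatter), each within the scatter. A second trifluoromethyl group on this ring is therefore expected to give a step of about a number 0.5 percentage points higher from compound 3 to compound 4 (within the scatter), not beyond the scatter. For compound 4 the estimate in this assay is 72%, with a range from 62% to 82%.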

Compound 4, a percentage reported as activity, at one concentration (the size of the read-out at that concentration, not a potency): 68.9%
The estimate for compound 4 lay 3.1 percentage points above the measured number; the range from low to high includes it.
By their numbers in this assay, from the lowest: compounds 1, 4, 2 and 3 (each within the scatter of the next).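

In this assay, trifluoromethyl in place of hydrogen on the ring at the aromatic nitrogen, meta to a trifluoromethyl group, gives a number 2.6 percentage points lower from compound 3 to compound 4 (within the scatter) and so does not separate compound 4 from compound 3. Compound 4 is the only compound shown with two substituents on this ring, and the earlier compounds, each with a single substituent there, could not show that a second trifluoromethyl group is accommodated at this position without a step beyond the scatter. No measurement is available that would explain this result.

Whether an amine or a carboxylic acid at this position would give a step beyond the scatter remains open, as the substituents shown on this ring are only trifluoromethyl and nitrile. As far as these compounds go, with a single tested concentration, any difference in potency between these compounds also remains open.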